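Moving the methyl groups on the aryl ring of compound 1

The compounds below may be only part of what the source reports. "The series", "measured", "known", "first", "only" and "open" are said of these compounds alone.

Compound 1 `Cc1nc(-c2ccccc2)c(C(=O)N2CCN(c3cccc(C)c3C)CC2)o1`: 35 nM
Compound 2 `COc1cccc(N2CCN(C(=O)c3oc(C)nc3-c3ccccc3F)CC2)c1`: 56.1 nM
Compound 3 `COc1ccc(Cl)cc1N1CCN(C(=O)c2oc(C)nc2-c2ccccc2F)CC1`: 153 nM

In a functional assay on HL-60 cells (Homo sapiens) for inhibition, read by MTT assay, with a stated time of 72 h (on this read-out lower numbers stand for stronger inhibition and higher numbers for weaker inhibition), compound 1 gives the lowest number of the three measured compounds. Compound 2 sits closest, with a number that lies within the usual scatter of compound 1, so the two cannot be told apart. Compound 3 lies furthest away, beyond the scatter. Within the data shown here, the only single-step comparison among measured compounds is a 2.7-fold higher number from compound 2 to compound 3 (0.44 log units; beyond the scatter), a modest change that comes from swapping one aryl group on the ring nitrogen for another.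

Compound 4 `Cc1cc(C)cc(N2CCN(C(=O)c3oc(C)nc3-c3ccccc3)CC2)c1` is built from compound 1 with the same atoms joined differently: 3,5-dimethylphenyl in place of 2,3-dimethylphenyl on an amine nitrogen in a ring. Among the measured compounds shown here, no measured step shows this exact change, but the step from compound 2 to compound 3 shows that altering the substituents on the aryl ring attached to the ring nitrogen shifts the number only modestly. The same sort of shift is expected here, and its direction is uncertain, so compound 4 is expected to stay near compound 1 with a small rise as the more likely outcome, a 1.6-fold higher number from compound 1 to compound 4 (0.20 log units; within the scatter). Compound 4 is therefore estimated at 55 nM, expected to fall between 20 nM and 150 nM.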

Compound 4, half-maximal inhibitory concentration: 34.5 nM
The estimate for compound 4 lay 1.6-fold (0.20 log units) above the measured number; low and high end bracket the measured number.
By their numbers in this assay, from the lowest: compounds 4, 1 and 2 (each within the scatter of the next); then compound 3.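

In this assay, replacing 2,3-dimethylphenyl with 3,5-dimethylphenyl on the amine nitrogen in the ring gives a 1.0-fold lower number from compound 1 to compound 4 (0.01 log units; within the scatter), so the two compounds cannot be told apart. The earlier step from compound 2 to compound 3 changed which groups the aryl ring carried, whereas this step keeps the same atoms and changes only how the two methyl groups are arranged, showing that these two arrangements give indistinguishable numbers. Nothing available here explains why the number holds across this change.

Going by these compounds, the result covers only these two dimethylphenyl arrangements, so it remains open whether 2,6-dimethylphenyl, a ring with a single methyl group, or a ring with no methyl groups would also stay within the scatter of compound 1. On these data alone, it is equally open whether the aryl ring would tolerate a very different group, such as a carboxylic acid or an amine, and whether the same indifference to arrangement would hold for other substituents, such as the methoxy and chloro groups of compound 3.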